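The compounds below may be only part of what the source reports. "The series", "measured", "known", "first", "only" and "open" are said of these compounds alone.

Measured so far:
- compound 1 `CCOC(=O)CC1C(C(=O)OCC)=C(N)Oc2cccc(-c3ccccc3)c21`: 44300 nM
- compound 2 `CCOC(=O)CC1C(C(=O)OCC)=C(N)Oc2c(-c3ccccc3)cccc21`: 49800 nM
- compound 3 `CCOC(=O)C1=C(N)Oc2ccc(-c3ccccc3)cc2C1CC(=O)N1CCCCC1`: 58500 nM

All three values come from a functional assay on Jurkat cells (Homo sapiens) for cytotoxicity, with a stated time of 48 h; a higher number here means a weaker inhibitor, a lower number a stronger inhibitor. Compound 3 stands within the scatter of both other compounds, so these data give no ranking among the three.

The next compound to be measured is compound 4 `CCOC(=O)C1=C(N)Oc2ccc(-c3ccccc3)cc2C1CC(=O)N1CCOCC1`, which has morpholin-4-yl in place of piperidin-1-yl on a carbonyl carbon. Within the data shown here, the series holds no measured pair that isolates this change, so its effect cannot be read directly from the data. Among the measured compounds shown here, the only guide is the narrow spread of values, with compound 3 at 58500 nM lying within the scatter of compound 1 at 44300 nM despite their structural differences. No step beyond the scatter is therefore expected in this assay, and no direction is favoured. The expected change is a 1.0-fold higher number from compound 3 to compound 4 (0.01 log units; within the scatter). For compound 4 the estimated value is 60000 nM, with an expected range from 32000 nM to 100000 nM.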

Compound 4, half-maximal inhibitory concentration: > 100000 nM
Compound 4: no number, only a limit (the forecaster's own chance of this, stated with the estimate: 15%); middle value at least 1.6-fold (0.22 log units) away from the limit.
By their numbers in this assay, from the lowest: compounds 1, 2 and 3 (each within the scatter of the next). At a limit, above all of these: compound 4.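

In this assay compound 4 gives > 100000 nM, which is a limit of the assay and not a number. Among these compounds, this gives the only measured pair that isolates a single change, morpholin-4-yl in place of piperidin-1-yl on a carbonyl carbon, and it reads as an at least 1.7-fold higher number from compound 3 to compound 4 (0.23 log units; that floor lies within the scatter). The pair points towards a higher number with this change but does not establish a step beyond the scatter, and the full size of the step cannot be read because the value is a limit: the limit of > 100000 nM in this assay, at which 1 of the 4 values shown sits.

As far as these compounds go, how other groups on this carbonyl carbon would read remains open, for example piperazin-1-yl or an open-chain amine such as diethylamino. From the compounds shown here alone, whether the same change reads alike with the phenyl group placed as in compound 1 or compound 2 also remains open.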